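This account rests on a few compounds, and the source may have more. Where it says the series, first, only, none or still open, it means among the compounds named here.

Measured compounds:
Compound 1, `[N-]=[N+]=Nc1nccc2c1ncn2[C@H]1C[C@H](O)[C@@H](CO)O1`, gives 4% in a functional assay (Homo sapiens) for inhibition of Nucleic Acid, tested at 100 uM; on this read-out lower numbers stand for less inhibition and higher numbers for more inhibition at the one concentration tested (going by the name of the read-out).
Compound 2, `CSc1nccc2c1ncn2[C@H]1C[C@H](O)[C@@H](CO)O1`, gives 36% in this assay.

Compound 2 stands highest of the two numbers shown; its nearest neighbour is compound 1, and the one measured step, a number 32 percentage points higher from compound 1 to compound 2 (beyond the scatter), goes beyond the scatter and is large. That step exchanges the group on the aromatic carbon of the shared core.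

Compound 3, `OC[C@H]1O[C@@H](n2cnc3c(SCc4ccccc4)nccc32)C[C@@H]1O`, is not yet measured in this assay. It differs from compound 2 in one place: phenyl in place of hydrogen on a saturated chain carbon bound to a sulfur. Read one bond further out, this is methyl to benzyl, or methylsulfanyl to benzylsulfanyl.

Among the measured compounds shown here, no measured step touches the methyl on the sulfur; the only step on hand, a number 32 percentage points higher from compound 1 to compound 2 (beyond the scatter), concerns a different exchange at the aromatic carbon and therefore bears on compound 3 only loosely, by showing that changes at this side of the core can move the read-out strongly. With nothing closer to rest on, a modest rise is expected, a number 9 percentage points higher from compound 2 to compound 3 (within the scatter), with wide uncertainty in both directions. For compound 3 the estimate in this assay is 45%, between 15% and 75%.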

Compound 3, a percentage reported as inhibition, at one concentration (the size of the read-out at that concentration, not a potency): 18%
Compound 3: the middle estimate sits 27 percentage points above what was measured, and the stated range covers the measured number.
By their numbers in this assay, from the lowest: compound 1; then compound 3; then compound 2.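

With the sulfur kept in place, the change from methyl to benzyl gives a number 18 percentage points lower from compound 2 to compound 3 (beyond the scatter) in this assay, so the read-out depends on what the sulfur carries and not merely on a sulfur being there. Benzylsulfanyl still keeps an advantage over azido, with a number 14 percentage points higher from compound 1 to compound 3 (beyond the scatter) on this read-out, but that gain is smaller than the one seen with methylsulfanyl, where the exchange gives a number 32 percentage points higher from compound 1 to compound 2 (beyond the scatter) on the same read-out. Nothing available explains why adding phenyl on the saturated chain carbon bound to a sulfur lowers the number, so the drop stands as a bare observation.

Only methyl and benzyl are shown on the sulfur, so it remains open whether any group larger than methyl lowers the number or whether the phenyl ring itself is responsible, a question that ethyl or a longer saturated chain on the sulfur could help to settle. Also open, on these data alone, is how an amine on the same aromatic carbon, or a carboxylic acid on the phenyl ring of benzylsulfanyl, would read in this test.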